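The Same Swap Tried on a Second Core

This account rests on a few compounds, and the source may have more. Where it says the series, first, only, none or still open, it means among the compounds named here.

Compound 1 `Cc1[nH]c2ccc(F)cc2c(=O)c1Br` and compound 2 `CCCCC#Cc1c(C)[nH]c2ccc(F)cc2c1=O` are built on one core, while compound 3 `COc1cc2[nH]c(C)c(Br)c(=O)c2cc1Cl` is built on another; how the two cores differ is not broken down here. In a physicochemical assay for lipophilicity, at pH 7.4 (a higher number here means a more lipophilic compound, a lower number a more polar compound), compound 1 gives 1.61. In the same assay compound 2 gives 5.64. Compound 3 gives 0, the lowest of the three numbers, and its gaps to the other two are beyond the usual scatter. The change from compound 1 to compound 2 is hex-1-yn-1-yl in place of bromo on an aromatic carbon, and it produced the step of a number 4.03 log units higher from compound 1 to compound 2 (beyond the scatter). Compound 4 `CCCCC#Cc1c(C)[nH]c2cc(OC)c(Cl)cc2c1=O` has not yet been measured in this assay. It differs from compound 3 by hex-1-yn-1-yl in place of bromo on an aromatic carbon, which is the same change at the same place as the one seen on the first core. For compound 4 the expected step is a number 4.00 log units higher from compound 3 to compound 4 (beyond the scatter), resting on the step of a number 4.03 log units higher from compound 1 to compound 2 (beyond the scatter) observed once so far. Compound 4 is therefore estimated to land near 4, with a likely range from 3 to 5.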

Compound 4, distribution coefficient: 2.45
Beside the measured number, compound 4's estimate is 1.55 log units above it; the whole stated range lies above it.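

Swapping bromo for hex-1-yn-1-yl raised the number on the second core as well: in this assay the swap gave a number 2.45 log units higher from compound 3 to compound 4 (beyond the scatter), so the direction of the change carried over and the step was again large. Its size did not carry over unchanged, since this step is clearly smaller than a number 4.03 log units higher from compound 1 to compound 2 (beyond the scatter), which means a step read on one core cannot simply be added to a compound on another core in this series. Among the compounds shown here, with only one pair on each core, this shows neither how much the step varies between cores nor which difference between the two cores matters, and nothing available explains the smaller step.

A third core would show whether the step usually lies nearer one of these two results or outside both. On these data alone, it also remains open whether a different replacement for bromo at this place, such as an amine, a carboxylic acid or a longer chain such as oct-1-yn-1-yl, would give similar steps on both cores.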